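Half-life in mouse liver microsomes after a sulfonyl aryl swap

The compounds below may be only part of what the source reports. "The series", "measured", "known", "first", "only" and "open" are said of these compounds alone.

The account concerns two measured compounds and one awaiting measurement. Compound 1 `N#Cc1ncccc1S(=O)(=O)N1CCN(c2ccc(C(=O)NCc3ccc(F)cc3)nn2)CC1` was tested in an ADME assay on microsomes from liver (Mus musculus) for metabolic stability, read by LC-MS, using NADPH, tested at 10 uM (a lower number here means that the compound disappears faster, a higher number that the compound lasts longer), where compound 1 gives 0.0833 h. Compound 2 `Cc1ccccc1S(=O)(=O)N1CC2(CN(c3ccc(C(=O)NCc4ccc(F)cc4)nn3)C2)C1`, which carries a different core, gives in this assay a half-life of 0.0333 h. For the measured compounds named here, of the two numbers, that of compound 1 is the higher, and the gap between the two lies beyond the usual scatter; the two compounds differ in more than one place, so no single step connects them.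

Compound 3 `Cc1cc(F)ccc1S(=O)(=O)N1CCN(c2ccc(C(=O)NCc3ccc(F)cc3)nn2)CC1` is built on the core of compound 1 and differs from it in one place: 4-fluoro-2-methylphenyl in place of 2-cyanopyridin-3-yl on a sulfonyl sulfur. Going by the values given here, no measured pair shows this change on its own, so there is no step to lean on. In this assay compound 3 is expected to stay close to compound 1, with a step from compound 1 to compound 3 of a 1.3-fold lower number from compound 1 to compound 3 (0.11 log units; within the scatter), a shift that would not reach beyond the scatter in either direction. The estimated half-life for compound 3 is 0.065 h, within a range from 0.025 h to 0.17 h.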

Compound 3, half-life: 0.25 h
Estimate against measurement, compound 3: 3.8-fold (0.59 log units) below, outside the stated range (above it).
By their numbers in this assay, from the lowest: compound 2; then compound 1; then compound 3.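

With the core of compound 1 held fixed, putting 4-fluoro-2-methylphenyl in place of 2-cyanopyridin-3-yl on the sulfonyl sulfur gives in this assay a 3.0-fold higher number from compound 1 to compound 3 (0.48 log units; beyond the scatter), a modest step. The earlier pair differed in more than one place and could not isolate this position, whereas this single change shows that the group on the sulfonyl sulfur can by itself move the half-life beyond the usual scatter. No information is available here that accounts for the size or direction of this step.

The change exchanges the whole aryl group at once, removing the nitrile and the ring nitrogen while adding the methyl and the fluorine, so the compounds shown do not assign the step to any one of these parts. Also open, going by these compounds, are whether a chlorine atom or a methoxy group in place of the fluorine would give a half-life like that of compound 3, and whether the same change would give a similar step on the core of compound 2.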